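The source may report more compounds than this note shows. Statements on the series, on what has been measured and on what is new or still open speak of the compounds shown alone.

Compound 1 `CC(C)Nc1nc(NCc2ccco2)c2cc(Cl)ccc2n1` and compound 2 `CC(C)Nc1nc(NCc2ccco2)c2c(Cl)cccc2n1` are built from the same atoms joined differently; how the two cores differ is not broken down here. In a physicochemical assay for solubility, at pH 7.4 (a higher number here means a more soluble compound, a lower number a less soluble compound), compound 1 gives <= 20000 nM, which is a limit of the assay. In this assay compound 2 gives <= 10000 nM, also a limit. Compound 3 `Cc1ccc2nc(NC(C)C)nc(NCc3ccco3)c2c1` carries methyl in place of chloro on an aromatic carbon, and in this assay compound 3 gives <= 20000 nM, a limit as well. The step that the two limits leave unreadable from compound 1 to compound 3 therefore cannot be read, since (the limit of <= 20000 nM in this assay, at which 2 of the 3 values shown sit). Compound 4 `Cc1cccc2nc(NC(C)C)nc(NCc3ccco3)c12` carries the same kind of change relative to compound 2, (methyl in place of chloro on an aromatic carbon), the place here being ortho to a fused ring and meta to a fused ring rather than meta to a fused ring and para to a fused ring. The expectation for compound 4 rests only on the limit that compound 2 shows, because of the limit of <= 10000 nM in this assay, at which 1 of the 3 values shown sits. Compound 4 is expected to give 5000 nM in this assay, a step estimated at a step that the limit leaves unreadable from compound 2 to compound 4, and most probably again only a limit.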

Compound 4, solubility: <= 10000 nM
Compound 4: no number, only a limit; the forecaster's own chance of this, stated with the estimate: 70%; the middle value lies beyond the limit too.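

Within the data shown here, compound 2 and compound 4 both stand only as limits in this assay, and no step between them can be read. The compounds shown leave open the actual solubility of all four, and what methyl in place of chloro does to it.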